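Adding a side chain to compound 1

The source may report more compounds than this note shows. Statements on the series, on what has been measured and on what is new or still open speak of the compounds shown alone.

Measured in a functional assay on CCRF-CEM cells (Homo sapiens) for inhibition; on this read-out higher numbers stand for weaker inhibition and lower numbers for stronger inhibition:
- compound 1 `Cn1cc(C#N)c2ccc(Nc3ncc(-c4ccccc4)o3)cc21`: 8000 nM
- compound 2 `Cn1cc(C#N)c2ccc(Nc3ncc(-c4ccc(CNC(=O)c5ccccc5)cc4)o3)cc21`: > 10000 nM (a limit, not a number)
- compound 3 `Cn1cc(C#N)c2ccc(Nc3ncc(-c4ccccc4CNC(=O)OCCC#N)o3)cc21`: > 10000 nM (a limit, not a number)

For the measured compounds named here, compound 1, at 8000 nM, is the only compound here with an actual number. Compound 2 and compound 3 both stop at the limit of > 10000 nM in this assay, at which 2 of the 3 values shown sit.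

Compound 4 `Cn1cc(C#N)c2ccc(Nc3ncc(-c4cccc(CNC(=O)OC5CCOC5)c4)o3)cc21` keeps the core of compound 1 and carries one change: ((((oxolan-3-yl)oxy)carbonyl)amino)methyl in place of hydrogen on an aromatic carbon. It adds ((((oxolan-3-yl)oxy)carbonyl)amino)methyl in place of hydrogen on an aromatic carbon, meta to a large group.

Going by the values given here, two measured steps bear on this. The closer one is an at least 1.2-fold higher number from compound 1 to compound 3 (0.09 log units; that floor lies within the scatter), as its added group also ends in a carbonyl, amino and methyl chain. The other is an at least 1.2-fold higher number from compound 1 to compound 2 (0.09 log units; that floor lies within the scatter). Both are only floors within the scatter, but neither addition gave a value under the limit.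

The step expected in this assay is therefore small and upward: a 1.3-fold higher number from compound 1 to compound 4 (0.10 log units; within the scatter). A reading at the limit is quite likely. The estimate for compound 4 is 10000 nM, with an expected range from 4000 nM to 20000 nM.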

Compound 4, half-maximal inhibitory concentration: > 10000 nM
Compound 4 was reported as a limit; the forecaster's own chance of this, stated with the estimate: 65%; the middle value lies on the limit itself.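

In this assay, compound 4 is reported only as a limit, not as a number. Placing ((((oxolan-3-yl)oxy)carbonyl)amino)methyl on this aromatic carbon, meta to a large group, gives an at least 1.2-fold higher number from compound 1 to compound 4 (0.09 log units; that floor lies within the scatter), so the true size of the step remains unknown and only its floor can be read. This side chain, with its five-membered non-aromatic ring, therefore also gives no value under the limit, and the added compound extends the count at that ceiling: the limit of > 10000 nM in this assay, at which 3 of the 4 values shown sit.

From the compounds shown here alone, how far compound 2, compound 3 and compound 4 lie past the limit stays open, so the three side chains cannot be ranked against one another. Also open, going by these compounds, is whether a plain aminomethyl group or a carboxylic acid on this same carbon would give a measurable number.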